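Saturating the exocyclic double bond of compound 2

A few compounds are considered here, and "the series" means these few. Any claim that something is new, unique, unknown or untested is made for them only; others in the source may bear on it.

Measured in an ADME assay on the whole organism for pharmacokinetics, with Rattus norvegicus as the target, at a dose of 100 mg/kg by the oral route; a higher number here means more compound in the circulation at the dose given, a lower number less compound in the circulation:
compound 1 `Cc1c(C)c2c(c(C)c1O)CCC(C)(COc1ccc(/C=C3\SC(=O)NC3=O)cc1)O2` gives 2440 ng.h/mL
compound 2 `Cc1c(C)c2c(c(C)c1OCc1ccccc1)CCC(C)(COc1ccc(/C=C3\SC(=O)NC3=O)cc1)O2` gives 14400 ng.h/mL
compound 3 `Cc1c(C)c2c(c(C)c1OCc1ccccc1)CCC(C)(CN1CCC[C@H]1COc1ccc(/C=C3\SC(=O)N(C(=O)CC(O)C(=O)O)C3=O)cc1)O2` gives 44700 ng.h/mL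

Compound 2 stands second highest of the three numbers. For the measured compounds named here, compound 3 gives the higher number, and that gap is beyond the scatter; compound 3 differs from compound 2 in more than one place, so no single step is drawn between them. Going by the values given here, the one step in this set, a 5.9-fold higher number from compound 1 to compound 2 (0.77 log units; beyond the scatter), is modest and concerns the benzyl on the oxygen of the shared core.

Compound 4 `Cc1c(C)c2c(c(C)c1OCc1ccccc1)CCC(C)(COc1ccc(CC3SC(=O)NC3=O)cc1)O2` is not yet measured. It differs from compound 2 as follows: a group of 8 heavy atoms (4 carbon, 1 nitrogen, 2 oxygen, 1 sulfur; one five-membered non-aromatic ring with 2 hetero atoms) in place of a group of 8 heavy atoms (4 carbon, 1 nitrogen, 2 oxygen, 1 sulfur; one five-membered non-aromatic ring with 2 hetero atoms), on an aromatic carbon. Neither measured step bears on this change: the step from compound 1 to compound 2 leaves the five-membered ring untouched, and compound 3 offers no clean comparison. With no guide, the expected step of a 1.0-fold lower number from compound 2 to compound 4 (0.01 log units; within the scatter) is none beyond the scatter. The estimate for compound 4 is therefore 14000 ng.h/mL, within 5000 ng.h/mL to 40000 ng.h/mL.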

Compound 4, area under the concentration-time curve: 15800 ng.h/mL
For compound 4 the middle estimate is 1.1-fold (0.05 log units) below the measured one, and the stated range covers the measured number.
By their numbers in this assay, from the lowest: compound 1; then compounds 2 and 4 (each within the scatter of the next); then compound 3.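

In this assay, the (2,4-dioxo-1,3-thiazolidin-5-yl)methyl group on the aromatic carbon para to a large group, with 2 double bonds outside aromatic rings instead of 3, gives a 1.1-fold higher number from compound 2 to compound 4 (0.04 log units; within the scatter) and so shows that saturating the exocyclic double bond leaves the number within the scatter. For the compounds shown here, this is the first reading at this end of the molecule, since the earlier step, a 5.9-fold higher number from compound 1 to compound 2 (0.77 log units; beyond the scatter), concerned only the benzyl on the oxygen of the shared core. Nothing in the data at hand accounts for this result.

As far as these compounds go, it remains open whether the same saturation would read the same with the free hydroxyl of compound 1 or with the substituted ring nitrogen and acylated ring of compound 3. Also open, from the compounds shown here alone, is how the number would respond to a tetrazole in place of the (2,4-dioxo-1,3-thiazolidin-5-yl)methyl group.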